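Amide aryl change in the piperidinyloxyacetic acid series

The source may report more compounds than this note shows. Statements on the series, on what has been measured and on what is new or still open speak of the compounds shown alone.

Measured compounds:
compound 1 `Cc1ccc(N(CCN2CCC(OCC(=O)O)CC2)C(=O)c2ccc(Cl)cc2)cc1` — 690 nM
compound 2 `O=C(O)COC1CCN(CCN(C(=O)c2ccc(C(F)(F)F)cc2)c2ccc(Cl)cc2)CC1` — > 10000 nM

Among the compounds with values here, in a functional assay on a cell-free system (Platelet, plasma, Homo sapiens) for inhibition (a higher number here means a weaker inhibitor, a lower number a stronger inhibitor), compound 1 gives 690 nM, the only number among the two values shown. Compound 2 in this assay gives only a limit of the assay, > 10000 nM. That result stands at the limit of > 10000 nM in this assay, at which 1 of the 2 values shown sits. Within the data shown here, no step between measured compounds differing in one place is available, so no measured step guides the next change.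

Compound 3 `COc1ccc(C(=O)N(CCN2CCC(OCC(=O)O)CC2)c2ccc(C)cc2)cc1OC` remains to be measured. It differs from compound 1 by 3,4-dimethoxyphenyl in place of 4-chlorophenyl on a carbonyl carbon. Without a measured step of this kind, the size of the change is open; a shift toward weaker inhibition beyond the usual scatter is expected, a 2.9-fold higher number from compound 1 to compound 3 (0.46 log units; beyond the scatter). Compound 3 is expected to give 2000 nM in this assay, with a range from 500 nM to 10000 nM.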

Compound 3, half-maximal inhibitory concentration: > 3000 nM
Compound 3 was reported as a limit (the forecaster's own chance of this, stated with the estimate: 25%); at least 1.5-fold (0.17 log units) between middle value and limit.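

In this assay, within the data shown here, this is the first step at the carbonyl position with the rest of compound 1 held fixed: 3,4-dimethoxyphenyl in place of 4-chlorophenyl on a carbonyl carbon gives an at least 4.3-fold higher number from compound 1 to compound 3 (0.63 log units; beyond the scatter). Compound 2 differs from compound 1 in more than one place, so its value could not be tied to this position alone. Compound 3 gives only a limit of the assay, which fixes a smallest size for the step and no largest one: the limit of > 3000 nM in this assay, at which 1 of the 3 values shown sits.

Still open, on these data alone, is how far compound 3 lies past its limit, and whether the step comes from the loss of the chlorine or from the entry of the methoxy groups. A plain phenyl group or a phenyl group carrying a single methoxy on the same carbonyl carbon would separate these readings.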